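From methoxy to ethyl in compound 3

A few compounds are considered here, and "the series" means these few. Any claim that something is new, unique, unknown or untested is made for them only; others in the source may bear on it.

Compound 1 `Cc1ccc(NC(=O)c2cc(Oc3cnc(C(=O)N(C)C)cn3)c3cc(C)oc3c2)nc1`: 215000 nM
Compound 2 `COc1cnc(NC(=O)c2cc(Oc3cnc(C(=O)N(C)C)cn3)c3cc(C)oc3c2)cn1`: 25000 nM

In a physicochemical assay for solubility, measured as kinetic solubility (on this read-out lower numbers stand for lower solubility and higher numbers for higher solubility), compound 2 has the lower of the two numbers, at 25000 nM. Compound 3 `CCc1cnc(NC(=O)c2cc(Oc3cnc(C(=O)N(C)C)cn3)c3cc(C)oc3c2)cn1` carries ethyl in place of methoxy on an aromatic carbon. Within the data shown here, the only measured step, an 8.6-fold lower number from compound 1 to compound 2 (0.93 log units; beyond the scatter), came with 5-methoxypyrazin-2-yl in place of 5-methylpyridin-2-yl on an amide-type nitrogen, a wider swap than this one. It therefore bears only loosely on the new change and sets no firm direction. Only a small step is expected, a 1.2-fold higher number from compound 2 to compound 3 (0.08 log units; within the scatter), probably within the scatter. For compound 3 the estimated value is 30000 nM, with a range of 9000 nM to 100000 nM.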

Compound 3, solubility: 117000 nM
Compound 3: middle estimate off by 3.9-fold (0.59 log units), on the low side; measured number outside the range, above it.
By their numbers in this assay, from the lowest: compound 2; then compounds 3 and 1 (each within the scatter of the next).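

In this assay, this assay, changing only the group on this aromatic carbon gives a clear shift ((a 4.7-fold higher number from compound 2 to compound 3 (0.67 log units; beyond the scatter))), although methoxy and ethyl hold the same number of heavy atoms. The low number therefore does not follow from the 5-substituted pyrazin-2-yl group as such, since the other comparison ((a 1.8-fold lower number from compound 1 to compound 3 (0.26 log units; within the scatter))) stays within the scatter. No supporting measurement explains the shift. Still open, on these data alone, is how an amine, a chlorine or a longer chain at this position would compare with methoxy and ethyl.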